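This account rests on a few compounds, and the source may have more. Where it says the series, first, only, none or still open, it means among the compounds named here.

Going by the values given here, compound 1 `COc1ccc(CN(C(=O)CCl)c2cc(OC)c(OC)c(OC)c2)cc1O` stands lowest of the two numbers measured so far: in a functional assay on HCT-116 cells (Homo sapiens) for inhibition, read by MTT assay, with a stated time of 48 h (a higher number here means a weaker inhibitor, a lower number a stronger inhibitor), compound 1 gives 250 nM. Compound 2 `COc1ccc(CNc2cc(OC)c(OC)c(OC)c2)cc1` gives 18400 nM in this assay, a gap that lies well beyond the usual scatter. Compound 3 `COc1ccc(CN(C(=O)C[Se]C#N)c2cc(OC)c(OC)c(OC)c2)cc1O` has not yet been measured. Its structure differs from that of compound 1 in one place: a group of 3 heavy atoms (1 carbon, 1 nitrogen, 1 selenium; no ring) in place of one chlorine atom, on a saturated chain carbon bound to a carbonyl carbon. Among the compounds with values here, with no measured step of this kind to lean on, the expected step of a 1.7-fold lower number from compound 1 to compound 3 (0.22 log units; within the scatter) is small, toward a somewhat lower number, and may not pass beyond the scatter. The estimate for compound 3 in this assay is 150 nM, with a range from 40 nM to 700 nM.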

Compound 3, half-maximal inhibitory concentration: 310 nM
Estimate against measurement, compound 3: 2.1-fold (0.32 log units) below; measured number inside the range.
By their numbers in this assay, from the lowest: compounds 1 and 3 (each within the scatter of the next); then compound 2.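

On a saturated chain carbon bound to a carbonyl carbon, placing the group of carbon, nitrogen and selenium where the chlorine atom stood gives a 1.2-fold higher number from compound 1 to compound 3 (0.09 log units; within the scatter) in this assay. That step lies within the scatter, so this position accepts either group without a readable difference in this assay. Nothing measured here explains why the two compounds read alike. Going by these compounds, whether an amine, a carboxylic acid or a longer chain at this carbon would read the same remains open.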